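A few compounds are considered here, and "the series" means these few. Any claim that something is new, unique, unknown or untested is made for them only; others in the source may bear on it.

Working notes on the series.

Of the compounds shown here, three have been measured in a functional assay on K562 cells (Homo sapiens) for antiproliferative activity, read by fluorescence, with a stated time of 3 days; a lower number here means a stronger inhibitor, a higher number a weaker inhibitor. Compound 1 `CCCCCSc1nc(Nc2ccc(SC)cc2)c2cn[nH]c2n1` gives 19900 nM. Compound 2 `CCCCCSc1nc(OC(=O)c2ccccc2)c2cn[nH]c2n1` gives 19800 nM. Compound 3 `O=C(Oc1nc(SCCc2ccccc2)nc2[nH]ncc12)c1cc2ccccc2o1` gives 19800 nM. Among the compounds with values here, compound 3 stands level with compound 2 at the digits read, and the two are together the lowest of the three numbers, but the gap to compound 1 is within the scatter, so no compound can be set apart from the others on these figures; all three sit at much the same weak level.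

Compound 4 `CCCCCSc1nc(OC(=O)c2cc3ccccc3o2)c2cn[nH]c2n1` has not yet been measured. It differs from compound 3 in one place: propyl in place of phenyl on a saturated chain carbon, two bonds along the chain from a sulfur. The same exchange, seen one bond further out, reads as phenethylsulfanyl to pentylsulfanyl. Within the data shown here, no measured pair in the set isolates this change, so nothing in the data says how it reads out; compound 2 carries the pentylsulfanyl group and its value matches compound 3.

Given that, the step from compound 3 to compound 4 is expected to be none beyond the scatter, a 1.0-fold higher number from compound 3 to compound 4 (0.00 log units; within the scatter). Compound 4 is estimated at 20000 nM, in the range 9000 nM to 45000 nM.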

Compound 4, half-maximal inhibitory concentration: 19800 nM
Compound 4: middle estimate off by 1.0-fold (0.00 log units), on the high side, and the stated range covers the measured number.
By their numbers in this assay, from the lowest: compounds 2, 3, 4 and 1 (each within the scatter of the next).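

In this assay, within the data shown here, the step for propyl in place of phenyl on a saturated chain carbon, two bonds along the chain from a sulfur, reads no change at the digits printed from compound 3 to compound 4 (within the scatter), the first measured pair to isolate this change. The step for 1-benzofuran-2-yl in place of phenyl on a carbonyl carbon reads no change at the digits printed from compound 2 to compound 4 (within the scatter), so neither exchange moves the number beyond the scatter. Nothing measured in the series accounts for this flat reading.

On these data alone, whether an amine or a carboxylic acid on that saturated chain carbon, or a pyridine ring on the carbonyl carbon, would read differently remains open. With no step beyond the scatter, the compounds shown do not tell which place, if any, governs the antiproliferative number.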